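Halogen Swap on the Phenoxy Tail

The source may hold more compounds than are shown below. What is called first, only, known or untested is meant among the compounds shown, and "the series" means these compounds.

Three compounds from this series have been examined in a functional assay on HepG2 cells (Homo sapiens) for antiproliferative activity, read by MTT assay, with a stated time of 72 h; on this read-out higher numbers stand for weaker inhibition and lower numbers for stronger inhibition:

compound 1 `CC(C)(C)c1ccc(OCCCON2C(N)=NC(N)=NC23CCSCC3)cc1`: 70 nM
compound 2 `NC1=NC2(CCOCC2)N(OCCCOc2ccc(Cl)cc2)C(N)=N1`: "not determined" (no result reported)
compound 3 `NC1=NC2(CCSCC2)N(OCCCOc2ccc(Br)cc2)C(N)=N1`: 1400 nM

Compound 2 stands nowhere on these numbers, since no result was reported for it, so the step from compound 2 to compound 4 `NC1=NC2(CCOCC2)N(OCCCOc2cccc(Br)c2)C(N)=N1` starts from an unknown point. The change is 3-bromophenyl in place of 4-chlorophenyl on an oxygen on a saturated carbon. Among the compounds with values here, no measured step matches this change directly. Within the data shown here, the only step among the measured compounds, a 20-fold higher number from compound 1 to compound 3 (1.30 log units; beyond the scatter), shows that placing a bromine on this aromatic ring, in exchange for tert-butyl, coincides with a large loss of activity in this assay, and compound 3 carries a bromophenoxy tail of the same kind as compound 4, though on a different core. Compound 3 gives 1400 nM in this assay. Among the measured compounds shown here, since the starting value of compound 2 is unknown, no direction of the step can be stated; the expectation for compound 4 rests on the weak activity of compound 3 alone. Compound 4 is therefore expected to give about 1500 nM in this assay, with a plausible range from 400 nM to 6000 nM.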

Compound 4, half-maximal inhibitory concentration: 320 nM
Estimate against measurement, compound 4: 4.7-fold (0.67 log units) above; the measured number lies below the stated range.
By their numbers in this assay, from the lowest: compound 1; then compound 4; then compound 3.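

Compound 2 has no reported result in this assay, so no new step can be read for compound 4, which at 320 nM stands without a measured partner that differs in one place. The compounds shown leave open whether 3-bromophenyl in place of 4-chlorophenyl raises, lowers or leaves unchanged the number in this assay. No supporting data bear on this result.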